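A few compounds are considered here, and "the series" means these few. Any claim that something is new, unique, unknown or untested is made for them only; others in the source may bear on it.

In a functional assay on MIA PaCa-2 cells (Homo sapiens) for cytotoxicity, read by MTT assay, with a stated time of 72 h (on this read-out lower numbers stand for stronger inhibition and higher numbers for weaker inhibition), compound 1 (`COC1=CC(=O)c2c(COc3ccc([N+](=O)[O-])cc3)c(C)n(C)c2C1=O`) gives 355 nM and compound 2 (`COC1=CC(=O)c2c(COc3ccccc3)c(C)n(C)c2C1=O`) gives 409 nM on the shared core, with a 1.2-fold higher number from compound 1 to compound 2 (0.06 log units; within the scatter) as the whole gap between them. Compound 3 (`COC1=CC(=O)c2c(COc3ccc(N)cc3)c(C)n(C)c2C1=O`) gives 160 nM as the lowest of the three numbers. Compound 4 (`COC1=CC(=O)c2c(COc3ccc(C#N)cc3)c(C)n(C)c2C1=O`) differs from compound 3 by cyano in place of amino on an aromatic carbon in a single change, cyano in place of amino on an aromatic carbon. The measured steps that bear on this are a 2.2-fold lower number from compound 1 to compound 3 (0.35 log units; beyond the scatter) and a 2.6-fold lower number from compound 2 to compound 3 (0.41 log units; beyond the scatter) and both are modest, each ending at the amino compound. Among the measured compounds shown here, no cyano compound has been measured, but compound 1 at 355 nM and compound 2 at 409 nM both lack amino, so a modest rise of similar size is expected in this assay rather than no change. The expected change is a 2.2-fold higher number from compound 3 to compound 4 (0.34 log units; beyond the scatter) in this estimate. The estimate for compound 4 is 350 nM with 170 nM to 720 nM as its expected range.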

Compound 4, half-maximal inhibitory concentration: 192 nM
Compound 4: the middle estimate sits 1.8-fold (0.26 log units) above what was measured; the measured number falls inside the stated range.
By their numbers in this assay, from the lowest: compounds 3, 4, 1 and 2 (each within the scatter of the next, the first and the last beyond it).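

In this assay the step from amino to cyano at this place on the aromatic ring is small: a 1.2-fold higher number from compound 3 to compound 4 (0.08 log units; within the scatter) shows the two groups cannot be told apart here, so the earlier drop from hydrogen to amino does not belong to amino alone. Cyano in place of hydrogen gives a 2.1-fold lower number from compound 2 to compound 4 (0.33 log units; beyond the scatter) and is a modest step beyond the scatter, whereas cyano in place of nitro gives a 1.8-fold lower number from compound 1 to compound 4 (0.27 log units; within the scatter) and does not separate those two groups, even though nitro itself stayed within the scatter of hydrogen. No measurement at hand accounts for this pattern.

The compounds shown leave open whether a hydroxyl, a methoxy or a carboxylic acid at this place would fall with amino and cyano or with hydrogen. They also leave open whether the same changes would hold elsewhere on the aromatic ring.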